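Quinolinone imines: alkyl in place of aryl

The source may report more compounds than this note shows. Statements on the series, on what has been measured and on what is new or still open speak of the compounds shown alone.

The shared core of compound 1 `Cc1ccc2[nH]c(=O)c(/C=N/c3ccc(C(=O)O)cc3)cc2c1`, compound 2 `O=c1[nH]c2ccccc2cc1/C=N/Cc1ccccc1` and compound 3 `Cc1ccc2[nH]c(=O)c(/C=N/Nc3ccc([N+](=O)[O-])cc3[N+](=O)[O-])cc2c1` is tested in a functional assay, read by spectrophotometry, with a stated time of 5 min; on this read-out higher numbers stand for weaker inhibition and lower numbers for stronger inhibition. In this assay compound 2 gives 329000 nM, the lower of the two numbers in hand. Compound 1 gives 409000 nM in this assay, and the gap to compound 2 lies within the scatter, so no order between them can be read. For the measured compounds named here, compound 3 is reported in this assay as "not active" (no number reported), without a single number, so it contributes no step.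

Compound 4 `CCCC/N=C/c1cc2ccccc2[nH]c1=O` has not yet been measured in this assay. It differs from compound 2 by propyl in place of phenyl on a saturated chain carbon bound to a double-bonded nitrogen. Going by the values given here, no step between two measured compounds bears on that change, and the two numbers in hand sit close together, so there is no basis for expecting a large move in either direction. The expectation for the step from compound 2 to compound 4 is one of no change beyond the scatter, a 1.2-fold higher number from compound 2 to compound 4 (0.08 log units; within the scatter). Compound 4 is therefore estimated to give 400000 nM in this assay, with a range from 150000 nM to 1500000 nM, the wider upper end allowing that a compound in this weak region may return only a limit.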

Compound 4, half-maximal inhibitory concentration: 246000 nM
For compound 4 the middle estimate is 1.6-fold (0.21 log units) above the measured one; the measured number falls inside the stated range.
By their numbers in this assay, from the lowest: compounds 4, 2 and 1 (each within the scatter of the next).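

In this assay, for the compounds shown here, the exchange of phenyl for propyl on a saturated chain carbon bound to a double-bonded nitrogen gives a 1.3-fold lower number from compound 2 to compound 4 (0.13 log units; within the scatter), the first step between two measured compounds that differ in one place. At this place, therefore, the six-membered aromatic ring of carbon only can give way to an open chain with fewer heavy atoms without a change that can be read, and no order can be assigned between the two compounds, with compound 4 at 246000 nM in a range of numbers that remains high on this read-out. Going by these compounds alone, no measurement in hand accounts for this result, so the step records only that this exchange is tolerated here.

Open, going by these compounds, is whether a longer chain, a branched chain, or a chain ending in an amine or a carboxylic acid at this place would move the number beyond the scatter. Also open is what the methyl on the core of compound 1 contributes, as the compounds shown include no pair that differs by that group alone.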